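This account rests on a few compounds, and the source may have more. Where it says the series, first, only, none or still open, it means among the compounds named here.

In an ADME assay on THP-1 cells (Homo sapiens) for cytotoxicity, read by CellTiter-Glo, with a stated time of 3 days (a higher number here means a weaker inhibitor, a lower number a stronger inhibitor), compound 1 `COc1ccc(/C=C/C(C)=N/NC(N)=S)cc1OC` reaches only a limit of > 11000 nM and gives no exact number. Compound 2 `COc1ccc(/C=C/C(C)=N/Nc2nc(-c3ccc(OC)c(OC)c3)cs2)cc1OC` gives 38000 nM in this assay and holds the only exact figure so far, so it is a single fixed point with no firm ranking against compound 1. Compound 3 `COc1ccc(/C=C/C(C)=N/Nc2nc(-c3ccc(N)cc3)cs2)cc1OC` keeps the rest of compound 2 and changes one place. The change is 4-aminophenyl in place of 3,4-dimethoxyphenyl on an aromatic carbon and it puts 4-aminophenyl in place of 3,4-dimethoxyphenyl on an aromatic carbon of a five-membered aromatic ring with 1 nitrogen and 1 sulfur. Going by the values given here, no measured pair shows what this swap does, so only a small step toward a lower number in this assay is expected, close to the usual scatter. Going by these compounds, the estimated change is a 1.9-fold lower number from compound 2 to compound 3 (0.28 log units; within the scatter) and remains untested. For compound 3 the expected value is 20000 nM with an estimated range from 5000 nM to 60000 nM in this measurement.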

Compound 3, half-maximal inhibitory concentration: 11000 nM
Beside the measured number, compound 3's estimate is 1.8-fold (0.26 log units) above it; the measured number falls inside the stated range.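

In this assay, going by these compounds alone, this swap gives the first exact step at the aromatic carbon next to the ring nitrogen of the five-membered ring: with 4-aminophenyl in place of 3,4-dimethoxyphenyl, the step is a 3.5-fold lower number from compound 2 to compound 3 (0.54 log units; beyond the scatter). The group on this carbon therefore moves the cell read-out by more than repeated measurements would scatter, which a single exact value could not show. Compound 1 stands only at a limit and gives no second exact point: the limit of > 11000 nM in this assay, at which 1 of the 3 values shown sits.

The swap removes both methoxy groups and adds an amine in a single change, and the compounds shown do not separate these two parts. A plain phenyl or a 4-methoxyphenyl on the same carbon would tell them apart.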